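The compounds below may be only part of what the source reports. "The series", "measured", "known", "first", "only" and "open" are said of these compounds alone.

Four compounds share one core, differing only in how two acid groups on a side chain are capped. Compound 1 `CN(Cc1cnc2nc(N)nc(N)c2n1)c1ccc(C(=O)NC(CCC(=O)O)C(=O)OC(C)(C)C)cc1` carries a free acid and a tert-butyl ester; compound 2 `CN(Cc1cnc2nc(N)nc(N)c2n1)c1ccc(C(=O)NC(CCC(=O)OC(C)(C)C)C(=O)O)cc1` holds the same atoms joined differently, and the difference between the two cores is not broken down here. Compound 3 `COC(=O)CCC(NC(=O)c1ccc(N(C)Cc2cnc3nc(N)nc(N)c3n2)cc1)C(=O)OC(C)(C)C` is compound 1 with methyl in place of hydrogen on an oxygen next to a carbonyl group. Compound 4 `COC(=O)C(CCC(=O)OC(C)(C)C)NC(=O)c1ccc(N(C)Cc2cnc3nc(N)nc(N)c3n2)cc1` is compound 2 with the same change (methyl in place of hydrogen on an oxygen next to a carbonyl group).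

In a functional assay on L1210 cells (Mus musculus) for inhibition (on this read-out lower numbers stand for stronger inhibition and higher numbers for weaker inhibition), compound 1 gives 5.2 uM, compound 3 gives 9.7 uM and compound 2 gives 0.02 uM, the lowest of the three, beyond the scatter from both others. The change from compound 1 to compound 3 made a step of a 1.9-fold higher number from compound 1 to compound 3 (0.27 log units; within the scatter), which does not count as a real shift.

That small step suggests the same change might leave compound 2 largely unchanged. Yet compound 2 stands far apart from compound 1 and compound 3, and compound 4, like compound 3, will carry methyl on an oxygen next to a carbonyl group and no free acid, so some loss seems possible. Balancing both, the step from compound 2 to compound 4 in this assay is expected to be about a 25-fold higher number from compound 2 to compound 4 (1.40 log units; beyond the scatter), with wide uncertainty. Compound 4 is therefore estimated at 0.5 uM, between 0.03 uM and 8 uM.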

Compound 4, concentration for 50% inhibition: 4.9 uM
Compound 4: middle estimate off by 9.8-fold (0.99 log units), on the low side; measured number inside the range.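

In this assay, the same swap of methyl in place of hydrogen on an oxygen next to a carbonyl group, which turns a carboxy group into a methoxycarbonyl group, has a very different size on the two cores: the same change on two cores in this assay, a 1.9-fold higher number (0.27 log units; within the scatter) from compound 1 to compound 3 and a 250-fold higher number (2.39 log units; beyond the scatter) from compound 2 to compound 4, 130-fold (2.12 log units) apart, beyond the scatter of two such steps

On the core of compound 2 the swap gives a 250-fold higher number from compound 2 to compound 4 (2.39 log units; beyond the scatter), a large loss of inhibition, so the near silence of this change on the core of compound 1 cannot be carried over to the core of compound 2, even though the two cores hold the same atoms joined differently. Going by these compounds alone, this shows that, in this series, the effect of the swap depends on the core that carries it, but with only two pairs it gives no rule for any further core and does not show why the two cores part so widely.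

The compounds shown leave open whether a larger ester such as an ethyl ester, or a primary amide in place of the carboxy group, would follow the methyl on the core of compound 2. They also leave open how a compound with two free carboxylic acids, with no tert-butyl ester at either end, would stand against compound 2 in this assay.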